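This account rests on a few compounds, and the source may have more. Where it says the series, first, only, none or still open, it means among the compounds named here.

Measured in a toxicity assay on L02 cells (Homo sapiens) for cytotoxicity, read by MTT assay, with a stated time of 24 h (on this read-out lower numbers stand for higher toxicity in this test and higher numbers for lower toxicity in this test), so far:

compound 1 `CCCCS(=O)(=O)Oc1ccc(/C=C/C(=O)Nc2ccc(C)cc2)cc1OC`: 26800 nM
compound 2 `CCCCS(=O)(=O)Oc1ccc(/C=C/C(=O)Nc2ccc(CC)cc2)cc1OC`: 89000 nM
compound 3 `CCOC(=O)/C=C/c1ccc(OS(=O)(=O)c2ccc(Cl)cc2)c(OC)c1`: 137000 nM

Compound 2 differs from compound 1 only by methyl in place of hydrogen on a saturated chain carbon bound to an aromatic carbon. That single change gave a 3.3-fold higher number from compound 1 to compound 2 (0.52 log units; beyond the scatter), that is, compound 2 was less toxic to the liver cells than compound 1.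

Compound 3 rests on a different core; the difference between the two cores is not broken down here. Compound 4 `CCCOC(=O)/C=C/c1ccc(OS(=O)(=O)c2ccc(Cl)cc2)c(OC)c1` is to be measured in this assay and differs from compound 3 by methyl in place of hydrogen on a saturated chain carbon, two bonds along the chain from an oxygen next to a carbonyl group. This is the same kind of change as that from compound 1 to compound 2, but not the same: there the added methyl sat on a saturated chain carbon bound to an aromatic carbon, here it sits on a saturated chain carbon two bonds along the chain from an oxygen next to a carbonyl group.

For compound 4 the expected step is a 1.5-fold higher number from compound 3 to compound 4 (0.16 log units; within the scatter), set beside the earlier step and kept smaller because the step of a 3.3-fold higher number from compound 1 to compound 2 (0.52 log units; beyond the scatter) was seen on another core and at another place. Compound 4 is therefore estimated at 200000 nM, with a likely span from 90000 nM to 450000 nM.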

Compound 4, half-maximal cytotoxic concentration: 150000 nM
Compound 4: middle estimate off by 1.3-fold (0.12 log units), on the high side; the measured number falls inside the stated range.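

In this assay, going from ethoxy to propoxy gave a 1.1-fold higher number from compound 3 to compound 4 (0.04 log units; within the scatter), so this added methyl left the reading essentially unchanged. Set beside the earlier step, the same kind of change did not carry over from one core to the other: the same change on two cores in this assay, a 3.3-fold higher number (0.52 log units; beyond the scatter) from compound 1 to compound 2 and a 1.1-fold higher number (0.04 log units; within the scatter) from compound 3 to compound 4, 3.0-fold (0.48 log units) apart, beyond the scatter of two such steps

This shows that the size of the step seen on the core of compound 1 cannot simply be transferred to the core of compound 3, but it does not show whether the core or the place of the methyl accounts for the gap, as the two steps differ in both and each rests on a single pair of compounds.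

The compounds shown leave open whether a longer chain such as butoxy would also leave the reading unchanged, and what a carboxylic acid in place of the ester would do. On these data alone, it also remains open whether a propyl group at the place of the ethyl in compound 2 would continue the earlier step.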